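The source may report more compounds than this note shows. Statements on the series, on what has been measured and on what is new or still open speak of the compounds shown alone.

Measured so far in an ADME assay on the whole organism (Rattus norvegicus, strain Sprague-Dawley) for metabolic stability, read by LC-MS, with stated times of 5 min and 24 h, at a dose of 5 mg/kg by the oral route; on this read-out lower numbers stand for a shorter-lived compound and higher numbers for a longer-lived compound:
compound 1 `N#Cc1cnc(NC(=O)N2CCCc3cc(CN4CCOCC4=O)c(C=O)nc32)cc1S[C@H]1CCOC1`: 0.79 h
compound 2 `CO[C@H]1CCN(c2cc(NC(=O)N3CCCc4cc(CN5CCOCC5=O)c(C=O)nc43)ncc2C#N)C1`: 1.2 h

Compound 2, at 1.2 h, lies within the scatter of compound 1, so these two numbers do not separate. Compound 3 `N#Cc1cnc(NC(=O)N2CCCc3cc(CN4CCOCC4=O)c(C=O)nc32)cc1S[C@@H]1CCOC1` follows from compound 2 by (oxolan-3-yl)sulfanyl in place of 3-methoxypyrrolidin-1-yl on an aromatic carbon, ortho to a cyano group. Within the data shown here, one measured step bears on this, a 1.5-fold higher number from compound 1 to compound 2 (0.18 log units; within the scatter), the same exchange of groups run the other way. Among the measured compounds shown here, compound 1 and compound 3 carry the same group but differ at its defined stereocentre, and no measured pair shows what that difference does. In this assay the expected change is a 1.4-fold lower number from compound 2 to compound 3 (0.15 log units; within the scatter), with nothing expected beyond the scatter. For compound 3 the estimated value is 0.85 h, with an expected range of 0.45 h to 1.6 h.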

Compound 3, half-life: 0.96 h
Estimate against measurement, compound 3: 1.1-fold (0.05 log units) below; the range from low to high includes it.
By their numbers in this assay, from the lowest: compounds 1, 3 and 2 (each within the scatter of the next).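

In this assay, the configuration at the saturated ring carbon of (oxolan-3-yl)sulfanyl, on the aromatic carbon ortho to a cyano group, now has a direct reading, with a 1.2-fold higher number from compound 1 to compound 3 (0.08 log units; within the scatter) as the step. With the other drawn configuration, the exchange of 3-methoxypyrrolidin-1-yl for (oxolan-3-yl)sulfanyl gives a 1.3-fold lower number from compound 2 to compound 3 (0.10 log units; within the scatter) as its step, so neither form of the group separates from 3-methoxypyrrolidin-1-yl on this read-out. The stereocentre is the only variable in the first of these comparisons: the fact that compounds 1 and 3 differ only in the configuration as drawn.

Going by these compounds, whether any group at this position can move the half-life beyond the scatter stays open, for example a dimethylamino group or a longer alkoxy chain. The three compounds share the rest of the structure, so they say nothing about changes elsewhere on the core.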